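This account rests on a few compounds, and the source may have more. Where it says the series, first, only, none or still open, it means among the compounds named here.

Three compounds have so far been measured in an assay on cells for inhibition of thyroid peroxidase (Homo sapiens), with stated times of 10 min and 15 min; a higher number here means a weaker inhibitor, a lower number a stronger inhibitor:

Compound 1 `Nc1cc(Cc2ccn(Cc3cccc(Oc4ccccc4)c3)n2)c2nn[nH]c2n1` gives 1100 nM
Compound 2 `Nc1cc(Cc2ccn(-c3ccc(F)cc3)n2)c2nn[nH]c2n1` gives 700 nM
Compound 3 `Nc1cc(Cc2ccn(Cc3ccc4ccccc4c3)n2)c2nn[nH]c2n1` gives 1100 nM

Compound 1 stands level with compound 3 at the digits shown, and together they carry the highest numbers of the three. Compound 2 carries a lower number, but its gap to compound 1 lies within the usual scatter, so no order among the three can be read from these values. Compound 4 `Nc1cc(Cc2ccn(Cc3cccc(Cc4ccccc4)c3)n2)c2nn[nH]c2n1` differs from compound 1 in one place: benzyl in place of phenoxy on an aromatic carbon. Going by the values given here, no step between two measured compounds covers an exchange of this kind. The three measured compounds vary only at the outer end of the shared core, and their numbers all sit within the scatter of one another, which gives no ground for expecting a marked shift here. The step is estimated as a 1.1-fold lower number from compound 1 to compound 4 (0.04 log units; within the scatter), which amounts to none beyond the scatter. Compound 4 is thus expected to give about 1000 nM in this assay, with a range from 400 nM to 2500 nM.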

Compound 4, half-maximal inhibitory concentration: 1900 nM
For compound 4 the middle estimate is 1.9-fold (0.28 log units) below the measured one; low and high end bracket the measured number.
By their numbers in this assay, from the lowest: compounds 2, 1, 3 and 4 (each within the scatter of the next, the first and the last beyond it).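

In this assay, benzyl in place of phenoxy on an aromatic carbon, meta to a large group, gives a 1.7-fold higher number from compound 1 to compound 4 (0.24 log units; within the scatter), and this step stays within the scatter. Going by these compounds alone, it is the first exchange that can be read in one place. Phenoxy counts one hydrogen-bond acceptor and benzyl none, yet this exchange at this position produces no step beyond the scatter, and nothing measured on either group bears on the result.

The compounds shown leave open whether a group of another kind at this position, such as an amine, a carboxylic acid or a longer chain, would give a step beyond the scatter. They also leave open whether benzyl in place of phenoxy would give a similar step on a different core.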